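The source may report more compounds than this note shows. Statements on the series, on what has been measured and on what is new or still open speak of the compounds shown alone.

Measured in an ADME assay on microsomes from liver (Rattus norvegicus) for metabolic stability; a higher number here means that the compound lasts longer, a lower number that the compound disappears faster:
- compound 1 `CC(C)[C@@H](c1ccc(-c2ccc3cccc(F)c3c2)[nH]c1=O)[C@@H]1OC(=O)NC1=O` gives 1.27 h
- compound 2 `CC(C)/C(=C1/SC(=O)NC1=O)c1ccc(-c2ccc3cccc(F)c3c2)[nH]c1=O` gives > 3 h as a limit of the assay
- compound 3 `CC(C)[C@@H](c1ccc(-c2ccc3cccc(F)c3c2)[nH]c1=O)[C@H]1OC(=O)NC1=O` gives 1.93 h

Compound 3 and compound 1 lie within the scatter of each other, and compound 2 stands as a limit only. Compound 4 `CC(C)[C@H](C[C@@H]1OC(=O)NC1=O)c1ccc(-c2ccc3cccc(F)c3c2)[nH]c1=O` differs from compound 3 thus: (2,4-dioxo-1,3-oxazolidin-5-yl)methyl in place of 2,4-dioxo-1,3-oxazolidin-5-yl on a saturated chain carbon bound to an aromatic carbon and a saturated chain carbon with (2,4-dioxo-1,3-oxazolidin-5-yl)methyl in place of 2,4-dioxo-1,3-oxazolidin-5-yl on a saturated chain carbon bound to an aromatic carbon and a saturated chain carbon. Among the compounds with values here, the one measured step of a 1.5-fold higher number from compound 1 to compound 3 (0.18 log units; within the scatter) comes with the fact that compounds 1 and 3 differ only in the configuration as drawn and gives no size for a change of this kind. No step beyond the scatter is therefore expected in this assay and no direction can be given, so compound 3 at 1.93 h serves as the anchor. The expected step is a 1.1-fold lower number from compound 3 to compound 4 (0.06 log units; within the scatter) and stays within the scatter. The estimate for compound 4 is 1.7 h with an expected range of 0.8 h to 3.5 h in this read-out.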

Compound 4, half-life in the Rattus norvegicus assay: 0.503 h
Compound 4: the middle estimate sits 3.4-fold (0.53 log units) above what was measured; the measured number lies below the stated range.
By their numbers in the Rattus norvegicus assay, from the lowest: compound 4; then compounds 1 and 3 (each within the scatter of the next). At a limit, above all of these: compound 2.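

In the Rattus norvegicus assay, (2,4-dioxo-1,3-oxazolidin-5-yl)methyl in place of 2,4-dioxo-1,3-oxazolidin-5-yl gives a 3.8-fold lower number from compound 3 to compound 4 (0.58 log units; beyond the scatter) and a 2.5-fold lower number from compound 1 to compound 4 (0.40 log units; beyond the scatter), so this change on the saturated chain carbon registers beyond the scatter, whereas a 1.5-fold higher number from compound 1 to compound 3 (0.18 log units; within the scatter) did not. In a physicochemical assay for solubility, measured as kinetic solubility, at pH 2 (on this read-out higher numbers stand for higher solubility and lower numbers for lower solubility), compound 3 gives 5400 nM and compound 4 gives 25100 nM as measured. The same pair moves the opposite way in the physicochemical assay, so half-life and solubility part at this position: the measured solubility of compound 3, 5400 nM, and of compound 4, 25100 nM, a 4.6-fold higher number (0.67 log units; beyond the scatter)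

Compound 4 is the only compound shown with this methyl-linked ring, so its other configurations remain open. On these data alone, whether a longer chain carrying the same ring, or an amine in its place, would shift either read-out also remains open.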